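Replacing the Dichlorophenylamino Arm with Phenyl on the Carbonyl

A few compounds are considered here, and "the series" means these few. Any claim that something is new, unique, unknown or untested is made for them only; others in the source may bear on it.

Of the compounds shown here, three sharing one core have been tested in a functional assay on A549 cells (Homo sapiens) for inhibition, read by sulforhodamine B assay, with a stated time of 48 h; on this read-out lower numbers stand for stronger inhibition of growth and higher numbers for weaker inhibition of growth. Compound 1 `COc1cc(-c2nn(-c3cccc(NC(=O)Nc4cc(C(F)(F)F)cc(C(F)(F)F)c4)c3)cc2-c2ccncc2)ccc1Cl` gives 527 nM. Compound 2 `COc1cc(-c2nn(-c3cccc(NC(=O)Nc4ccc(Cl)c(Cl)c4)c3)cc2-c2ccncc2)ccc1Cl` gives 745 nM, the highest of the three numbers; compound 1 is nearest, and compound 3 `O=C(Nc1cccc(-n2cc(-c3ccncc3)c(-c3ccc(Cl)c(O)c3)n2)c1)Nc1cc(C(F)(F)F)cc(C(F)(F)F)c1` at 298 nM is furthest, beyond the scatter. Among the measured compounds shown here, the one measured step, a 1.8-fold lower number from compound 1 to compound 3 (0.25 log units; within the scatter), concerns hydrogen in place of methyl on an oxygen on an aromatic ring and lies within the scatter.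

Compound 4 `COc1cc(-c2nn(-c3cccc(NC(=O)c4ccccc4)c3)cc2-c2ccncc2)ccc1Cl` differs from compound 2 by phenyl in place of (3,4-dichlorophenyl)amino on a carbonyl carbon; cut one bond further out, this reads ((3,4-dichlorophenyl)carbamoyl)amino to benzamido. For the measured compounds named here, no measured step touches this part of the molecule, so the step from compound 1 to compound 3 gives no direct guide. With the (3,4-dichlorophenyl)amino group removed and compound 2 already giving 745 nM, compound 4 is expected to give a higher number, estimated at 2000 nM with a range from 600 nM to 8000 nM, an expected step of a 2.7-fold higher number from compound 2 to compound 4 (0.43 log units; beyond the scatter).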

Compound 4, concentration for 50% growth inhibition: 585 nM
For compound 4 the middle estimate is 3.4-fold (0.53 log units) above the measured one; the measured number lies below the stated range.
By their numbers in this assay, from the lowest: compounds 3, 1, 4 and 2 (each within the scatter of the next, the first and the last beyond it).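

In this assay, phenyl in place of (3,4-dichlorophenyl)amino on a carbonyl carbon gives a 1.3-fold lower number from compound 2 to compound 4 (0.11 log units; within the scatter), so this pair cannot be told apart on this read-out. At this position, then, the amino nitrogen, with its hydrogen-bond donor, and the chlorine atoms can all go together without a change beyond the scatter, a result the step on the oxygen elsewhere in the molecule could not show. No independent measurement bears on why the number holds across this change.

On these data alone, the pair changes the nitrogen and the chlorine atoms at once, so their separate contributions remain open; a dichlorophenyl group directly on the carbonyl, or a plain phenylamino group, would pull them apart. Also open, as far as these compounds go, is how a much smaller group on this carbonyl, such as methyl, or a group carrying an amine would read out.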